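Changing the aryl group on the ring amine nitrogen

The source may hold more compounds than are shown below. What is called first, only, known or untested is meant among the compounds shown, and "the series" means these compounds.

Compound 1, `Nc1scc(CN2CCN(c3cc(Cl)cc(Cl)c3)CC2)c1C(=O)c1ccc(Cl)cc1`, gives 1% in an assay on CHO cells for displacement of a labelled ligand from adenosine receptor A3 (Homo sapiens), read by scintillation counting, with a stated time of 120 min, tested at 10 uM; a higher number here means more inhibition at the concentration tested (going by the name of the read-out), a lower number less inhibition.
Compound 2, `Nc1scc(CN2CCN(c3ccc([N+](=O)[O-])cc3)CC2)c1C(=O)c1ccc(Cl)cc1`, gives 2% in this assay.
Compound 3, `Nc1scc(CN2CCN(c3cccc(C(F)(F)F)c3)CC2)c1C(=O)c1ccc(Cl)cc1`, gives 0% in this assay.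

All three share one core and differ only in the aryl group on the amine nitrogen in the ring. Compound 1 stands second highest of the three numbers, but neither neighbour is separated from it: the step of a number 1 percentage points higher from compound 1 to compound 2 (within the scatter) and the step of a number 1 percentage points lower from compound 1 to compound 3 (within the scatter) both lie within the scatter, as does the step of a number 2 percentage points lower from compound 2 to compound 3 (within the scatter). In plain terms, none of the three aryl groups tried so far produces measurable displacement at the concentration tested.

Compound 4, `Nc1scc(CN2CCN(c3c(F)cc(F)cc3F)CC2)c1C(=O)c1ccc(Cl)cc1`, is the next variant at the same position: 2,4,6-trifluorophenyl in place of 3,5-dichlorophenyl on an amine nitrogen in a ring. The three measured steps are the ones that bear on this change, since each also exchanges the aryl group on that nitrogen, and each was within the scatter at a level close to zero. A fourth aryl group is therefore expected to behave the same way, with no step beyond the scatter, a number 1 percentage points higher from compound 1 to compound 4 (within the scatter). Compound 4 is estimated at 2%, with a range from -8% to 12%.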

Compound 4, a percentage reported as inhibition, at one concentration (the size of the read-out at that concentration, not a potency): 0%
Compound 4: the middle estimate sits 2 percentage points above what was measured; the measured number falls inside the stated range.
By their numbers in this assay, from the lowest: compounds 3, 4, 1 and 2 (each within the scatter of the next).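

Fluorine on the aryl ring, in the 2,4,6-trifluorophenyl group, adds a new kind of substituent at this position, yet the result shows a number 1 percentage points lower from compound 1 to compound 4 (within the scatter) and no change at the digits printed from compound 3 to compound 4 (within the scatter) and a number 2 percentage points lower from compound 2 to compound 4 (within the scatter) in this assay. All six pairs among the four compounds now lie within the scatter, so 3,5-dichlorophenyl, 4-nitrophenyl, 3-(trifluoromethyl)phenyl and 2,4,6-trifluorophenyl on this ring nitrogen cannot be told apart, and a read-out this close to zero gives no ranking to build on. Nothing available explains why the numbers stay so low.

On these data alone, it remains open whether a group of another type on this nitrogen, such as a benzyl group, a pyridine ring, an acetyl group or a simple methyl, would give a number clearly separated from these four. As far as these compounds go, it is equally open whether changes elsewhere on the shared core, for instance replacing the 4-chlorophenyl group on the carbonyl with an unsubstituted phenyl or a methoxyphenyl group, would do so while this aryl group stays the same.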